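A few compounds are considered here, and "the series" means these few. Any claim that something is new, unique, unknown or untested is made for them only; others in the source may bear on it.

Measured compounds:
Compound 1, `O=C(C1CCCCC1)N1CC(c2nc(-c3cccc(F)c3)no2)C1` – > 10000 nM in an assay on HEK293 cells for negative allosteric modulation of metabotropic glutamate receptor 5 (Homo sapiens), read by FLIPR (a lower number here means a stronger inhibitor, a higher number a weaker inhibitor), a limit of the assay.
Compound 2, `O=C(C1CCC(F)(F)CC1)N1CC(c2nc(-c3cccc(F)c3)no2)C1` – > 10000 nM in this assay, a limit of the assay.
Compound 3, `CC1CCCCC1C(=O)N1CC(c2nc(-c3cccc(F)c3)no2)C1` – > 10000 nM in this assay, a limit of the assay.

Compound 3 thus stands at the limit of this assay and carries no number of its own; the two other compounds share that position, as the limit of > 10000 nM in this assay, at which 3 of the 3 values shown sit, records. The step to compound 4, `Cc1ccc(C(=O)N2CC(c3nc(-c4cccc(F)c4)no3)C2)cc1`, is 4-methylphenyl in place of 2-methylcyclohexyl on a carbonyl carbon. Two of the measured steps touch the same region of the molecule: the step from compound 2 to compound 3, a step that the two limits leave unreadable from compound 2 to compound 3, exchanges one group on the carbonyl carbon for another, and the step from compound 1 to compound 3, a step that the two limits leave unreadable from compound 1 to compound 3, adds a methyl to the saturated ring. Because the limit of > 10000 nM in this assay, at which 3 of the 3 values shown sit, places all three values at the limit, neither step yields a readable size or direction. The step from compound 1 to compound 2, a step that the two limits leave unreadable from compound 1 to compound 2, is likewise unreadable. Going by the values given here, the exchange of a saturated ring for an aromatic one has no measured precedent here, so the expectation for compound 4 rests on little beyond the fact that every measured variant sits at the limit. Compound 4 is therefore estimated at 3000 nM, with a range from 300 nM to 10000 nM, and the expected step from compound 3 to compound 4 is an at least 3.3-fold lower number from compound 3 to compound 4 (0.52 log units; beyond the scatter).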

Compound 4, half-maximal inhibitory concentration: > 10000 nM
Compound 4: no number, only a limit; the forecaster's own chance of this, stated with the estimate: 55%; at least 3.3-fold (0.52 log units) between middle value and limit.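

In this assay compound 4 gives > 10000 nM, a limit of the assay. The steps to compound 4 from compound 1, compound 2 and compound 3 therefore cannot be read: the limit of > 10000 nM in this assay, at which 4 of the 4 values shown sit.

The compounds shown leave open whether any group on the carbonyl carbon would give a number rather than a limit in this assay.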